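Adding a Second Trifluoromethyl to Compound 3

The source may report more compounds than this note shows. Statements on the series, on what has been measured and on what is new or still open speak of the compounds shown alone.

In a functional assay on MCF7 cells (Homo sapiens) for inhibition, read by MTT assay, with a stated time of 72 h (on this read-out lower numbers stand for stronger inhibition and higher numbers for weaker inhibition), compound 2 `COc1cc(NC(C)CCCNC(=O)Nc2cccc(C(F)(F)F)c2)c2ncccc2c1` gives 3300 nM, while compound 1 `COc1cc(NC(C)CCCNC(=O)Nc2cc(C(F)(F)F)cc(C(F)(F)F)c2)c2ncccc2c1` gives 1600 nM. The change between them is trifluoromethyl in place of hydrogen on an aromatic carbon, and it made a 2.1-fold lower number from compound 2 to compound 1 (0.31 log units; beyond the scatter). Compound 3 `COc1cc(NC(C)CCCNC(=O)NNC(=O)Nc2cccc(C(F)(F)F)c2)c2ncccc2c1` gives 190 nM in this assay, the lowest of the three numbers; how its core differs from that of compound 2 is not broken down here. Compound 4 `COc1cc(NC(C)CCCNC(=O)NNC(=O)Nc2cc(C(F)(F)F)cc(C(F)(F)F)c2)c2ncccc2c1` has not yet been measured. It differs from compound 3 by trifluoromethyl in place of hydrogen on an aromatic carbon, the same change as from compound 2 to compound 1, in the same surroundings. Because compound 3 already gives 190 nM and because the earlier step was a 2.1-fold lower number from compound 2 to compound 1 (0.31 log units; beyond the scatter), compound 4 is expected to follow with a 2.1-fold lower number from compound 3 to compound 4 (0.32 log units; beyond the scatter). Compound 4 is therefore estimated at 90 nM, between 40 nM and 220 nM.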

Compound 4, half-maximal inhibitory concentration: 2400 nM
The estimate for compound 4 lay 27-fold (1.43 log units) below the measured number; measured number outside the range, above it.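

In this assay, trifluoromethyl in place of hydrogen on an aromatic carbon gave a 13-fold higher number from compound 3 to compound 4 (1.10 log units; beyond the scatter), so the change did not carry over from one core to the other in either direction or size: the same change on two cores in this assay, a 2.1-fold lower number (0.31 log units; beyond the scatter) from compound 2 to compound 1 and a 13-fold higher number (1.10 log units; beyond the scatter) from compound 3 to compound 4, 26-fold (1.42 log units) apart, beyond the scatter of two such steps. In this series, then, the step measured on the core of compound 2 was no guide to the same step on the core of compound 3. These two pairs do not show why the steps part, nor how the change would behave on any further core.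

The compounds shown leave open whether a chlorine or a methyl group at that place on the core of compound 3 would give a step like that of trifluoromethyl. They also leave open how a longer chain in the core would alter that step.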